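The source may report more compounds than this note shows. Statements on the series, on what has been measured and on what is new or still open speak of the compounds shown alone.

Measured in a functional assay on MCF7 cells (Homo sapiens) for antiproliferative activity, read by MTT assay, with a stated time of 48 h; a lower number here means a stronger inhibitor, a higher number a weaker inhibitor:
- compound 1 `COc1ccc(C(=O)c2ccc(OC)c3c2OC(C)(C)C=C3)c(NC(=O)CBr)c1`: 2360 nM
- compound 2 `C=C(c1ccc(OC)cc1NC(=O)CO)c1ccc(OC)c2c1OC(C)(C)C=C2`: 100 nM
- compound 3 `C=C(c1cc(OC)c(OC)c(OC)c1)c1ccc(OC)cc1NC(=O)CO`: 110 nM

Compound 3 at 110 nM lies within the scatter of compound 2 at 100 nM. Compound 1 at 2360 nM stands at a much higher number than compound 3, a gap beyond the scatter.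

The next compound is compound 4 `C=C(c1cc(OC)c(OC)c(OC)c1)c1ccc(OC)cc1NC(=O)CN`, which carries amino in place of hydroxy on a saturated chain carbon bound to a carbonyl carbon. Everything else in compound 3 is kept. Among the compounds with values here, no measured pair shows this exchange, so the size of the step in this assay cannot be read from the data. The expectation is a small move toward a higher number, probably not beyond the scatter, and it is anchored on compound 3 at 110 nM. The expected step is a 1.4-fold higher number from compound 3 to compound 4 (0.13 log units; within the scatter). Compound 4 is estimated at 150 nM, with an expected range of 45 nM to 500 nM.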

Compound 4, half-maximal inhibitory concentration: 190 nM
For compound 4 the middle estimate is 1.3-fold (0.10 log units) below the measured one, within the range that was stated.
By their numbers in this assay, from the lowest: compounds 2, 3 and 4 (each within the scatter of the next); then compound 1.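

Within the data shown here, this is the first pair that differs only on the saturated chain carbon bound to a carbonyl carbon. In this assay, amino in place of hydroxy gives a 1.7-fold higher number from compound 3 to compound 4 (0.24 log units; within the scatter), so the two groups cannot be told apart at this position in this assay. With one heavy atom exchanged and the hydrogen-bond donor and acceptor counts unchanged, the step marks hydroxy and amino as interchangeable here for compound 3 and compound 4 only, and no other measurement bears on the result.

On these data alone, whether the same exchange gives a similar step on the core of compound 2 remains open. Also open, as far as these compounds go, is how a dimethylamino group, a carboxylic acid or a longer chain would read out on this carbon.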